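The source may report more compounds than this note shows. Statements on the series, on what has been measured and on what is new or still open speak of the compounds shown alone.

Compound 1 `COc1cccc(OC)c1OCCNCCOc1ccccc1OCc1ccccc1Cl` gives 8.59 in a functional assay on thoracic aorta for antagonist activity at Alpha-1D adrenergic receptor (Rattus norvegicus); on this read-out lower numbers stand for lower potency and higher numbers for higher potency (the scale is a negative logarithm). Compound 2 `COc1cccc(OC)c1OCCNCCOc1ccccc1OCc1ccc(Cl)cc1` gives 9.11 in the same assay.

Compound 2 stands highest of the two measured compounds, with compound 1 nearest. Compound 3 `COc1cccc(OC)c1OCCNCCOc1ccccc1OCc1ccccc1C` differs from compound 2 by 2-methylphenyl in place of 4-chlorophenyl on a saturated chain carbon bound to an oxygen on an aromatic ring. Among the measured compounds shown here, one measured step bears on this change: a number 0.52 log units higher from compound 1 to compound 2 (beyond the scatter), where moving the chlorine from the 2-position to the 4-position of the phenyl ring raised potency. Compound 3 returns a substituent to the 2-position, so a step of similar size in the opposite direction is expected: a number 0.46 log units lower from compound 2 to compound 3 (beyond the scatter). Compound 3 is therefore estimated at 8.65, with a range from 8.1 to 9.2.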

Compound 3, negative logarithm of the antagonist equilibrium constant: 8.64
Estimate against measurement, compound 3: 0.01 log units above, and the stated range covers the measured number.
By their numbers in this assay, from the lowest: compounds 1 and 3 (each within the scatter of the next); then compound 2.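

The 2-methylphenyl group of compound 3 falls with the 2-chlorophenyl group of compound 1 and not with the 4-chlorophenyl group of compound 2 (the step is a number 0.47 log units lower from compound 2 to compound 3 (beyond the scatter)). Methyl in place of chloro on an aromatic carbon makes no readable difference here (a number 0.05 log units higher from compound 1 to compound 3 (within the scatter)), so among these three compounds only the 4-chlorophenyl group stands apart. No measurement at hand accounts for this.

Going by these compounds, whether the gain belongs to the 4-substituted ring or to chloro itself stays open, and 4-methylphenyl would separate the two. On these data alone, how a polar group such as an amine or a carboxylic acid on this ring would read also remains open.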